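Ring for chain at the aryl ether oxygen

The source may report more compounds than this note shows. Statements on the series, on what has been measured and on what is new or still open speak of the compounds shown alone.

Measured compounds:
compound 1 `CCCOc1ccc(Cc2ccc(NC3=NCCN3)cc2)cc1` — 8.8
compound 2 `CCCCOc1ccc(Cc2ccc(NC3=NCCN3)cc2)cc1` — 9
compound 3 `CCCCCCOc1ccc(Cc2ccc(NC3=NCCN3)cc2)cc1` — 8.2

These three compounds were run in a functional assay on SH-SY5Y cells (Homo sapiens) for antagonist activity, read by cAMP accumulation; on this read-out higher numbers stand for higher potency (the scale is a negative logarithm) and lower numbers for lower potency. Compound 2 gives the highest of the three numbers, but its lead over compound 1 is a number 0.20 log units higher from compound 1 to compound 2 (within the scatter), so the two cannot be ordered. Compound 3 lies further off: a number 0.80 log units lower from compound 2 to compound 3 (beyond the scatter), and against compound 1 it reads a number 0.60 log units lower from compound 1 to compound 3 (beyond the scatter).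

Compound 4 `c1cc(NC2=NCCN2)ccc1Cc1ccc(OC2CCCCC2)cc1` differs from compound 2 by cyclohexyl in place of butyl on an oxygen on an aromatic ring. The measured steps along the chain bear on it only in part: adding one carbon changed nothing beyond the scatter, while two or three more carbons lowered the number modestly. Among the measured compounds shown here, the entering group carries as many carbons as the chain of compound 3, but as a ring, for which no precedent exists here. A small loss is therefore expected, the step from compound 2 being estimated at a number 0.40 log units lower from compound 2 to compound 4 (beyond the scatter). Compound 4 is expected to give about 8.6, within 8 to 9.2.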

Compound 4, negative logarithm of the antagonist equilibrium constant: 8.6
For compound 4 middle estimate and measured number coincide at the digits printed, within the range that was stated.
By their numbers in this assay, from the lowest: compound 3; then compounds 4, 1 and 2 (each within the scatter of the next, the first and the last beyond it).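

In this assay, this first ring at the oxygen on the aromatic ring shows that the position takes cyclohexyl as well as an open chain: against propyl the change reads a number 0.20 log units lower from compound 1 to compound 4 (within the scatter), and against butyl it reads a number 0.40 log units lower from compound 2 to compound 4 (beyond the scatter). The comparison with the longest chain adds a second point, a number 0.40 log units higher from compound 3 to compound 4 (beyond the scatter), so cyclohexyl and hexyl do not give the same number at this position. Nothing measured here accounts for this difference between ring and chain.

The compounds shown leave open whether a smaller ring, such as cyclopentyl or cyclopropylmethyl, would read closer to butyl than cyclohexyl does. They also leave open how a flat phenyl ring or a tetrahydropyranyl ring, which carries an oxygen of its own, would compare at this oxygen.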